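Methoxy for nitro on a benzylsulfanyl arm

A few compounds are considered here, and "the series" means these few. Any claim that something is new, unique, unknown or untested is made for them only; others in the source may bear on it.

Compound 1, `CCCSc1nc2nc(C)cc(N3CC[C@@H](C)[C@@H](N(C)c4ncnc5[nH]ccc45)C3)n2n1`, in a functional assay on HGC-27 cells (Homo sapiens) for inhibition, read by MTT assay, with a stated time of 72 h (on this read-out lower numbers stand for stronger inhibition and higher numbers for weaker inhibition), gives 20900 nM.
Compound 2, `Cc1cc(N2CC[C@@H](C)[C@@H](N(C)c3ncnc4[nH]ccc34)C2)n2nc(SCc3nc4ccccc4[nH]3)nc2n1`, in this assay reaches only the assay limit of > 100000 nM.
Compound 3, `Cc1cc(N2CC[C@@H](C)[C@@H](N(C)c3ncnc4[nH]ccc34)C2)n2nc(SCc3ccc([N+](=O)[O-])cc3)nc2n1`, in this assay gives 29400 nM.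

Compound 3 holds the highest of the two numbers; compound 1 is its nearest neighbour, and a 1.4-fold higher number from compound 1 to compound 3 (0.15 log units; within the scatter) lies within the scatter. Against compound 2 the picture is different, with an at least 3.4-fold lower number from compound 2 to compound 3 (0.53 log units; beyond the scatter). Compound 4, `COc1ccc(CSc2nc3nc(C)cc(N4CC[C@@H](C)[C@@H](N(C)c5ncnc6[nH]ccc56)C4)n3n2)cc1`, differs from compound 3 by methoxy in place of nitro on an aromatic carbon. Neither measured step touches this aromatic carbon: the step from compound 1 replaces the whole 4-nitrophenyl group, and the step from compound 2 exchanges 1H-benzimidazol-2-yl for it. The steps therefore give no direction for a change within the 4-nitrophenyl group itself, and in this assay only a small step, likely within the scatter, is expected. Compound 4 is estimated at 25000 nM, between 9000 nM and 70000 nM, which would be an expected step of a 1.2-fold lower number from compound 3 to compound 4 (0.07 log units; within the scatter).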

Compound 4, half-maximal inhibitory concentration: 18200 nM
For compound 4 the middle estimate is 1.4-fold (0.14 log units) above the measured one; low and high end bracket the measured number.
By their numbers in this assay, from the lowest: compounds 4, 1 and 3 (each within the scatter of the next). At a limit, above all of these: compound 2.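

At this aromatic carbon, the first change within the 4-nitrophenyl group itself stays inside the scatter in this assay, with a 1.6-fold lower number from compound 3 to compound 4 (0.21 log units; within the scatter), so methoxy and nitro are not told apart here. The 4-methoxyphenyl arm is likewise not told apart from the arm of compound 1, with a 1.1-fold lower number from compound 1 to compound 4 (0.06 log units; within the scatter), while the 1H-benzimidazol-2-yl arm remains separate, with an at least 5.4-fold lower number from compound 2 to compound 4 (0.73 log units; beyond the scatter). Compound 2 remains a limit and not a number: the limit of > 100000 nM in this assay, at which 1 of the 4 values shown sits.

Going by these compounds, whether an amine or a carboxylic acid at this aromatic carbon would move the number beyond the scatter stays open.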